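The compounds below may be only part of what the source reports. "The series", "measured", "known", "first", "only" and "open" are said of these compounds alone.

Measured compounds:
- compound 1, `O=C(NC1CCN(Cc2ccc3ccccc3c2)CC1)c1ccccc1`, 347 nM
- compound 2, `CCOc1cc(OCC)cc(C(=O)NC2CCN(Cc3ccc4ccccc4c3)CC2)c1`, 56 nM
- compound 3, `O=C(NC1CCN(Cc2ccc3ccccc3c2)CC1)c1ccc(F)cc1`, 36 nM

In an assay on isolated protein for binding affinity to melanin-concentrating hormone receptor 1 (Homo sapiens) (on this read-out lower numbers stand for stronger inhibition and higher numbers for weaker inhibition), compound 3 carries the lowest number of the three, but compound 2 sits so close that the two cannot be told apart, while compound 1 stands clearly apart with a much higher number. Among the compounds with values here, the one single-point step among the measured compounds runs a 9.6-fold lower number from compound 1 to compound 3 (0.98 log units; beyond the scatter), and it is the only step that bears on the change considered here.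

Compound 4, `O=C(NC1CCN(Cc2ccc3ccccc3c2)CC1)c1ccc(Cl)cc1`, differs from compound 3 in one place: chloro in place of fluoro on an aromatic carbon. Within the data shown here, no measured pair shows a halogen swapped for another halogen, so the expectation rests on the fact that a halogen at this position already carries compound 3 well past compound 1, and on the usual experience that one halogen for another is a small move. The estimate for compound 4 is therefore a step of a 1.4-fold lower number from compound 3 to compound 4 (0.16 log units; within the scatter), within or near the scatter, and compound 4 is expected to give about 25 nM in this assay, between 8 nM and 80 nM.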

Compound 4, inhibition constant: 232 nM
Estimate against measurement, compound 4: 9.3-fold (0.97 log units) below, and the stated range ends below it.
By their numbers in this assay, from the lowest: compounds 3 and 2 (each within the scatter of the next); then compounds 4 and 1 (each within the scatter of the next).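

In this assay, chloro in place of fluoro gives a 6.4-fold higher number from compound 3 to compound 4 (0.81 log units; beyond the scatter), so at this place, on an aromatic carbon para to a large group, one halogen cannot simply stand in for the other. Chloro in place of hydrogen gives a 1.5-fold lower number from compound 1 to compound 4 (0.17 log units; within the scatter), which means that the advantage compound 3 holds over compound 1 belongs to fluoro and is not shared by chloro. Nothing shown here explains why these two halogens differ at this place.

Still open, on these data alone, is how bromo, methyl, methoxy or a nitrile would compare at this same place. Also open, as far as these compounds go, is whether the step from fluoro to chloro would keep its size if the rest of the molecule were changed.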